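The source may report more compounds than this note shows. Statements on the series, on what has been measured and on what is new or still open speak of the compounds shown alone.

Measured compounds in a functional assay (B cells) with Mus musculus as the target; a lower number here means that less compound is needed, a higher number that more compound is needed for the effect:
Compound 1 `CCCn1c(=O)n(C2CCC(COC(C)=O)O2)c2nc(NC(C)=O)nc(O)c21` gives 154 uM in this assay.
Compound 2 `C=CCn1c(=O)n(C2CN(CCCC)CC(CO)O2)c2nc(N)nc(O)c21` gives 5 uM in this assay.
Compound 3 `Nc1nc(O)c2c(n1)n(C1OC(CO)[C@@H](O)[C@H]1O)c(=O)n2CC(O)CSc1ccccc1` gives 142 uM in this assay.

Compound 3 holds the second highest of the three numbers. Its value and that of compound 1 lie within the scatter of each other, while compound 2 sits far lower, beyond the scatter. Compound 4 `Cn1c(=O)n(C2OC(CO)[C@@H](O)[C@H]2O)c2nc(N)nc(O)c21` is the unmeasured analogue of compound 3, differing by hydrogen in place of 1-hydroxy-2-(phenylsulfanyl)ethyl on a saturated chain carbon bound to an aromatic nitrogen. For the measured compounds named here, no directly comparable step among the measured compounds exists, so the change is untested here. With the large group gone, the account expects compound 4 to remain near compound 3, with a step of a 1.4-fold higher number from compound 3 to compound 4 (0.15 log units; within the scatter) that is small and, if anything, toward a higher number. The estimate for compound 4 in this assay is 200 uM, ranging from 60 uM to 600 uM.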

Compound 4, concentration for half-maximal effect: 10 uM
Estimate against measurement, compound 4: 20-fold (1.30 log units) above, and the stated range ends above it.
By their numbers in this assay, from the lowest: compounds 2 and 4 (each within the scatter of the next); then compounds 3 and 1 (each within the scatter of the next).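

In this assay, hydrogen in place of 1-hydroxy-2-(phenylsulfanyl)ethyl on a saturated chain carbon bound to an aromatic nitrogen gives a 14-fold lower number from compound 3 to compound 4 (1.15 log units; beyond the scatter) and is the first change shown at this position. The large group, with its aromatic ring and sulfur, is therefore not required for a low number here, and its presence goes with a much higher one. Nothing given here accounts for the size of this step. As far as these compounds go, it remains open which part of the group, the hydroxyl or the phenylsulfanyl, carries the step. Also open, from the compounds shown here alone, is whether an amine or a carboxylic acid at this place would keep the lower number.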